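Chloro in place of hydrogen on compound 2

The compounds below may be only part of what the source reports. "The series", "measured", "known", "first", "only" and "open" are said of these compounds alone.

Compound 2 `S=C(Nc1ccccc1)Nc1nc2ccccc2s1` was tested in a functional assay on THP-1 cells (Homo sapiens) for cytotoxicity, read by MTT assay, with a stated time of 48 h (on this read-out higher numbers stand for weaker inhibition and lower numbers for stronger inhibition), where compound 2 gives 36500 nM, the higher of the two numbers shown. Compound 1 `S=C(Nc1ccccc1)Nc1nc2c(Cl)cccc2s1` gives 31800 nM, and the step of a 1.1-fold higher number from compound 1 to compound 2 (0.06 log units; within the scatter) marks hydrogen in place of chloro on an aromatic carbon. Compound 3 `Cc1ccc2nc(NC(=S)Nc3ccccc3)sc2c1` returns only a limit of the assay, > 50000 nM. The step of an at least 1.3-fold higher number from compound 2 to compound 3 (0.13 log units; that floor lies within the scatter) marks methyl in place of hydrogen on an aromatic carbon. Compound 4 `S=C(Nc1ccc(Cl)cc1)Nc1nc2ccccc2s1` is not yet measured; it differs from compound 2 by chloro in place of hydrogen on an aromatic carbon, on a six-membered aromatic ring of carbon only, para to a large group. Neither measured step touches that ring, and both lie within the scatter, so no step beyond the scatter is expected. Compound 4 is therefore estimated at 35000 nM (range 15000 nM to 80000 nM), a step of a 1.0-fold lower number from compound 2 to compound 4 (0.02 log units; within the scatter) expected to stay within the scatter.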

Compound 4, half-maximal inhibitory concentration: 39000 nM
Compound 4: middle estimate off by 1.1-fold (0.05 log units), on the low side; the range from low to high includes it.
By their numbers in this assay, from the lowest: compounds 1, 2 and 4 (each within the scatter of the next). At a limit, above all of these: compound 3.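

Chloro in place of hydrogen on the six-membered aromatic ring of carbon only, para to a large group, gives a 1.1-fold higher number from compound 2 to compound 4 (0.03 log units; within the scatter) in this assay. The earlier steps shown here left this ring untouched, so this position now has a reading of its own, and with chloro there the number stays within the scatter of compound 2.

On these data alone, whether an amine or a carboxylic acid at this position would carry the number beyond the scatter stays open. Compound 3 gives only a limit, so the compounds shown do not all yield a number: the limit of > 50000 nM in this assay, at which 1 of the 4 values shown sits.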